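From piperidin-1-yl to azepan-1-yl on compound 2

A few compounds are considered here, and "the series" means these few. Any claim that something is new, unique, unknown or untested is made for them only; others in the source may bear on it.

In a functional assay on MCF7 cells (Homo sapiens) for inhibition, read by MTT assay, with stated times of 18 h and 4 h (on this read-out higher numbers stand for weaker inhibition and lower numbers for stronger inhibition), compound 1 (`CCCCCCCCCCOP(=O)(O)OCCSC(=S)N1CCCCCC1`) gives 43300 nM and compound 2 (`CCCCCCCCOP(=O)(O)OCCSC(=S)N1CCCCC1`) gives 26000 nM. Going by the values given here, these two values lie within the usual scatter of each other, so compound 2 stands level with the only other measurement available.

Compound 3 (`CCCCCCCCOP(=O)(O)OCCSC(=S)N1CCCCCC1`) carries azepan-1-yl in place of piperidin-1-yl on a thiocarbonyl carbon. Among the compounds with values here, no measured pair isolates this change, so the data do not fix its size. On these data alone, compound 1 also carries azepan-1-yl and gives 43300 nM, so no step beyond the scatter is expected in this assay, and the direction remains open. The estimate is a small 1.2-fold higher number from compound 2 to compound 3 (0.06 log units; within the scatter), which is expected to stay within the scatter. For compound 3 the expected value is 30000 nM, with an estimated range of 15000 nM to 58000 nM.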

Compound 3, half-maximal inhibitory concentration: 78000 nM
For compound 3 the middle estimate is 2.6-fold (0.41 log units) below the measured one, and the stated range ends below it.
By their numbers in this assay, from the lowest: compounds 2, 1 and 3 (each within the scatter of the next, the first and the last beyond it).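

In this assay, going by these compounds alone, azepan-1-yl in place of piperidin-1-yl on a thiocarbonyl carbon now has a measured size: a 3.0-fold higher number from compound 2 to compound 3 (0.48 log units; beyond the scatter) is a modest step beyond the scatter, and it is the first change isolated at this position. With azepan-1-yl held fixed, hydrogen in place of ethyl on a saturated chain carbon gives a 1.8-fold higher number from compound 1 to compound 3 (0.26 log units; within the scatter) and stays within the scatter, so the chain change shows no clear effect on this read-out. No supporting data account for the ring step.

On these data alone, whether the ring step carries over to the longer chain of compound 1 stays open. Also open, as far as these compounds go, is how a pyrrolidine or morpholine ring on the thiocarbonyl carbon, or a still longer chain, would read here.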